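Fluorophenyl to chlorophenyl step in the series

The source may report more compounds than this note shows. Statements on the series, on what has been measured and on what is new or still open speak of the compounds shown alone.

In a functional assay on HUVEC cells (Homo sapiens) for antiproliferative activity, read by MTT assay, with a stated time of 48 h (a higher number here means a weaker inhibitor, a lower number a stronger inhibitor), compound 1 (`Fc1ccc(/C=C/c2nnc(-c3ccc4c(c3)OCCO4)o2)cc1`) gives 4960 nM and compound 2 (`Fc1ccccc1/C=C/c1nnc(-c2ccc3c(c2)OCCO3)o1`) gives 1160 nM while compound 3 (`Fc1cccc(/C=C/c2nnc(-c3ccc4c(c3)OCCO4)o2)c1`) gives 3530 nM on the same scale. The standing of compound 3 comes from a 1.4-fold lower number from compound 1 to compound 3 (0.15 log units; within the scatter) together with a 3.0-fold higher number from compound 2 to compound 3 (0.48 log units; beyond the scatter) in this set, so it groups with compound 1 and not with compound 2.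

Compound 4 (`Clc1ccc(/C=C/c2nnc(-c3ccc4c(c3)OCCO4)o2)cc1`) carries 4-chlorophenyl in place of 3-fluorophenyl, with 4-chlorophenyl in place of 3-fluorophenyl on a double-bonded chain carbon bound to a double-bonded chain carbon as the counted difference, on a double-bonded chain carbon bound to a double-bonded chain carbon. Among the compounds with values here, no measured step exchanges fluorine for chlorine, so that part remains open. Only 2-fluorophenyl separates from the others beyond the scatter, as seen in a 4.3-fold lower number from compound 1 to compound 2 (0.63 log units; beyond the scatter) within this set, and compound 4 does not carry it. No step beyond the scatter is therefore expected in this assay for this change. The estimated step is a 1.1-fold higher number from compound 3 to compound 4 (0.03 log units; within the scatter) on present evidence. For compound 4 the estimated value is 3800 nM with an expected range from 1500 nM to 9000 nM in this read-out.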

Compound 4, half-maximal inhibitory concentration: 8030 nM
For compound 4 the middle estimate is 2.1-fold (0.32 log units) below the measured one, and the stated range covers the measured number.
By their numbers in this assay, from the lowest: compound 2; then compounds 3, 1 and 4 (each within the scatter of the next, the first and the last beyond it).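

In this assay, within the data shown here, chloro in place of fluoro on an aromatic carbon gives the first direct halogen exchange, and the result lies within the scatter, with a 1.6-fold higher number from compound 1 to compound 4 (0.21 log units; within the scatter). The steps from the other two fluorophenyl compounds lie beyond it, with a 2.3-fold higher number from compound 3 to compound 4 (0.36 log units; beyond the scatter) and a 6.9-fold higher number from compound 2 to compound 4 (0.84 log units; beyond the scatter), the latter being the largest step in the set. Among these compounds, the 4-chlorophenyl of compound 4 therefore groups with the 4-fluorophenyl of compound 1, while compound 2 remains the only compound separated from all others beyond the scatter.

No evidence bearing on the cause of these steps is available. From the compounds shown here alone, whether chloro in place of fluoro in compound 2 would keep its lower number remains open, as does the outcome with a methoxy group or an amine in place of the halogen.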